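This account rests on a few compounds, and the source may have more. Where it says the series, first, only, none or still open, it means among the compounds named here.

Compound 1 `Cc1cc(-c2ccc3[nH]ccc3c2)cn2c(CSCCc3ccccc3)cnc12` gives >= 20 ug/mL in an ADME assay on HEL cells (Homo sapiens) for cytotoxicity, with a stated time of 3 days; on this read-out lower numbers stand for higher toxicity in this test and higher numbers for lower toxicity in this test.
Compound 2 `Cc1cc(-c2ccoc2)cn2c(CSCCc3ccccc3)cnc12` gives > 4 ug/mL in this assay.

Both of these values are limits of the assay and not numbers. Compound 2 stands at a limit, its > 4 ug/mL being the limit described in the limit of > 4 ug/mL in this assay, at which 1 of the 2 values shown sits. Among the compounds with values here, the one other value shown, that of compound 1, is also a limit, the one described in the limit of >= 20 ug/mL in this assay, at which 1 of the 2 values shown sits. The step that the two limits leave unreadable from compound 1 to compound 2 is therefore not readable in size or direction.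

Compound 3 `Cc1cc(N2CCN(C)CC2)cn2c(CSCCc3ccccc3)cnc12` differs from compound 2 by 4-methylpiperazin-1-yl in place of furan-3-yl on an aromatic carbon. Within the data shown here, the only measured step bears on a different change and gives no number, so no size of step in this assay can be expected from the data, and no direction beyond the scatter is indicated. Compound 3 is estimated at 20 ug/mL, with a range from 5 ug/mL to 80 ug/mL. This estimate means an expected step that the limit leaves unreadable from compound 2 to compound 3.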

Compound 3, minimum cytotoxic concentration: 20 ug/mL
The estimate for compound 3 equals the measured number at the digits printed, within the range that was stated.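

In this assay, within the data shown here, compound 3 gives the only value at this position that is a number and not a limit of the assay, and it carries a six-membered non-aromatic ring, 4-methylpiperazin-1-yl, where the other two compounds carry aromatic groups. As far as these compounds go, replacing 1H-indol-5-yl with this ring reads only as a number no higher from compound 1 to compound 3 (the limit leaves the size open), so the direction is bounded but the size stays open. No size can be given for the replacement of furan-3-yl either, because compound 2 stands at a limit: the limit of > 4 ug/mL in this assay, at which 1 of the 3 values shown sits.

The compounds shown leave open whether the methyl group on the ring matters to this read-out, since the unsubstituted piperazine is not among them. They also leave open how an open-chain amine such as dimethylamino, or a morpholine ring, would read at this carbon.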